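Swapping cyano for chloro on a shared sulfonamide core

The source may hold more compounds than are shown below. What is called first, only, known or untested is meant among the compounds shown, and "the series" means these compounds.

In a functional assay on P388 cells (Mus musculus) for antiproliferative activity (on this read-out lower numbers stand for stronger inhibition and higher numbers for weaker inhibition), compound 1 `N#Cc1c[nH]c2c(NS(=O)(=O)c3ccc(C(N)=O)cc3)cccc12` gives 2.5 ug/mL and compound 2 `CS(=O)(=O)Nc1ccc(S(=O)(=O)Nc2cccc3c(C#N)c[nH]c23)cc1` gives 3.5 ug/mL. Among the compounds with values here, the two are the only measured compounds, and they sit within the usual scatter of each other, so neither can be ranked above the other.

Compound 3 `CS(=O)(=O)Nc1ccc(S(=O)(=O)Nc2cccc3c(Cl)c[nH]c23)cc1` differs from compound 2 in one place: chloro in place of cyano on an aromatic carbon of the five-membered aromatic ring with 1 nitrogen, two ring bonds from the ring nitrogen (chloro in place of cyano on an aromatic carbon).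

Within the data shown here, only one measured step is available, and it is a 1.4-fold higher number from compound 1 to compound 2 (0.15 log units; within the scatter). That step is methanesulfonamido in place of carbamoyl, at a different part of the molecule, so it shows only that this series tolerated one change without a clear shift. Among the measured compounds shown here, no measured pair shows what replacing cyano does, so the direction remains open and no shift beyond the scatter can be justified.

The expected step is therefore small, at a 1.8-fold lower number from compound 2 to compound 3 (0.24 log units; within the scatter), though this estimate is uncertain. For compound 3 the estimated value in this assay is 2 ug/mL, within an expected range of 0.4 ug/mL to 7 ug/mL.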

Compound 3, half-maximal inhibitory concentration: 1.6 ug/mL
Compound 3: the middle estimate sits 1.3-fold (0.10 log units) above what was measured; the range from low to high includes it.
By their numbers in this assay, from the lowest: compounds 3, 1 and 2 (each within the scatter of the next, the first and the last beyond it).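

Putting chloro in place of cyano on an aromatic carbon of the five-membered aromatic ring with 1 nitrogen, two ring bonds from the ring nitrogen, gives a 2.2-fold lower number from compound 2 to compound 3 (0.34 log units; beyond the scatter) in this assay and so shows that the group at this position can shift the read-out. Within the data shown here, the shift is modest, but it is the first single change here to lie beyond the scatter, whereas the earlier change elsewhere on the molecule gave a 1.4-fold higher number from compound 1 to compound 2 (0.15 log units; within the scatter) and stayed within it; it also shows that activity in this assay survives the loss of cyano, with its triple bond and its hydrogen-bond acceptor. Nothing available bears on why the number moved.

Among the compounds shown, this position carries only cyano and chloro, so it remains open whether the shift is particular to chloro or would also come with another group there, such as bromo, methyl or an amine. On these data alone, it is also open whether the same swap would give a similar step on the core of compound 1, which carries carbamoyl in place of methanesulfonamido.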